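Replacing a Pyrrolidine Ring and the Expected Solubility Shift

The compounds below may be only part of what the source reports. "The series", "measured", "known", "first", "only" and "open" are said of these compounds alone.

Of the compounds shown here, two have so far been measured in a physicochemical assay for solubility, measured as kinetic solubility; a lower number here means a less soluble compound, a higher number a more soluble compound. Compound 1 `O=C(Nc1ccnnc1)c1cc(N2CCCC2)ccc1OCc1ccccc1` gives 35000 nM in this assay, the higher of the two numbers. For the measured compounds named here, compound 2 `O=C(Nc1cccc(Cl)c1)c1cc(C(F)(F)F)ccc1OCc1ccccc1` gives 7000 nM in this assay, a lower figure that lies beyond the usual scatter; these two compounds differ in more than one place, so no single step links them. Compound 3 `CN1CC2(CCN(c3ccc(OCc4ccccc4)c(C(=O)Nc4ccnnc4)c3)CC2)C1` has not yet been measured. It differs from compound 1 by a group of 10 heavy atoms (8 carbon, 2 nitrogen; one four-membered non-aromatic ring with 1 hetero atom, one six-membered non-aromatic ring with 1 hetero atom) in place of a group of 5 heavy atoms (4 carbon, 1 nitrogen; one five-membered non-aromatic ring with 1 hetero atom), on an aromatic carbon. Going by the values given here, no step between two measured compounds shows what such a change does in this assay, so any forecast rests on the standing of compound 1 alone. In this assay the step is expected to be a moderate rise, a 2.6-fold higher number from compound 1 to compound 3 (0.41 log units; beyond the scatter), somewhat beyond the scatter. Compound 3 is therefore estimated at 90000 nM, with a range from 30000 nM to 250000 nM.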

Compound 3, solubility: 266000 nM
The estimate for compound 3 lay 3.0-fold (0.47 log units) below the measured number; measured number outside the range, above it.
By their numbers in this assay, from the lowest: compound 2; then compound 1; then compound 3.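

In this assay, replacing the pyrrolidin-1-yl group with a group holding a four-membered and a six-membered non-aromatic ring gives a 7.6-fold higher number from compound 1 to compound 3 (0.88 log units; beyond the scatter) on an otherwise unchanged compound. This single-place step shows that the position para to a benzyloxy group and meta to a (pyridazin-4-yl)carbamoyl group can carry this larger two-ring group, with a number that moves well beyond the scatter. No measurement shown here explains the rise.

Left open is which feature of the entering group goes with the higher number: its ring sizes, its total size or its methyl-bearing nitrogen. A piperidine ring or a morpholine ring at the same position would help to separate these features, and a single step cannot show whether the trend extends further.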